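Methylating One Hydroxyl of a Catechol-Bearing Styryl Acid

A few compounds are considered here, and "the series" means these few. Any claim that something is new, unique, unknown or untested is made for them only; others in the source may bear on it.

The compounds share one core, a bicyclic ring system carrying a carboxymethyl arm on its nitrogen and a carbonyl, with a styryl branch toward a substituted benzene ring. Compound 1 `COc1cc(/C=C/c2nc3cccnc3n(CC(=O)O)c2=O)ccc1O` carries a 4-hydroxy-3-methoxyphenyl end; compound 2 `O=C(O)Cn1c(=O)c(/C=C/c2ccc(O)c(O)c2)nc2cc(Cl)cnc21` carries a 3,4-dihydroxyphenyl end together with a chlorine on the core; compound 3 `O=C(O)Cn1c(=O)c(-c2ccccc2)nc2cccnc21` has a plain phenyl directly on the core, with no styryl link, and no result was reported for it.

In a functional assay, read by spectrophotometry, with a stated time of 30 min, tested at 50 uM (on this read-out lower numbers stand for a weaker effect and higher numbers for a stronger effect at the one concentration tested), compound 1 gives 75.6%, and compound 2 gives 87.4%. For compound 3 the outcome in this assay is given as "not determined" (no result reported), so no number is available for it. Among the measured compounds shown here, of the two numbers known, compound 2 stands highest, and its lead over compound 1 is beyond the usual scatter of repeated measurements.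

Compound 4 `COc1cc(/C=C/c2nc3cc(Cl)cnc3n(CC(=O)O)c2=O)ccc1O` has not yet been measured. It differs from compound 2 by methyl in place of hydrogen on an oxygen on an aromatic ring, so it keeps the chlorine of compound 2 while taking the 4-hydroxy-3-methoxyphenyl end of compound 1. Since compound 1, with the same end group but no chlorine, gives 75.6%, a moderate downward step is expected, possibly within the scatter. The expected step from compound 2 to compound 4 is a number 7.4 percentage points lower from compound 2 to compound 4 (within the scatter). Compound 4 is therefore estimated at 80%, with a range from 66% to 92%.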

Compound 4, a percentage reported as activity, at one concentration (the size of the read-out at that concentration, not a potency): 81.8%
Beside the measured number, compound 4's estimate is 1.8 percentage points below it; measured number inside the range.
By their numbers in this assay, from the lowest: compounds 1, 4 and 2 (each within the scatter of the next, the first and the last beyond it).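

Among the compounds shown here, compound 4 lets each change be read on its own, which the earlier compounds did not allow. In this assay, with the chlorine held in place, swapping hydrogen for methyl on an oxygen on an aromatic ring, which turns the 3,4-dihydroxyphenyl end into the 4-hydroxy-3-methoxyphenyl end, gives a number 5.6 percentage points lower from compound 2 to compound 4 (within the scatter) and so shows that this single change does not move the read-out clearly past the noise of the measurement; with that end group held in place, adding the chloro group on an aromatic carbon gives a number 6.2 percentage points higher from compound 1 to compound 4 (within the scatter) and likewise stays inside the noise. No measured property of these compounds is available to explain either step.

As far as these compounds go, it remains open whether a longer chain on that oxygen, such as ethyl, an amine in place of the hydroxy, or bromine in place of the chlorine would give a step beyond the scatter. From the compounds shown here alone, a reading at one concentration is also not a potency, so how these compounds compare across a range of concentrations is still unknown.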